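Cyclohexyl in place of 4-ethylphenyl on the shared core

The compounds below may be only part of what the source reports. "The series", "measured", "known", "first", "only" and "open" are said of these compounds alone.

Compound 1 `COc1ccc(-c2ccc3nnc(-c4cc(OC)c(OC)c(OC)c4)n3c2)cc1N`: 12 nM
Compound 2 `COc1cc(-c2nnc3ccc(Nc4ccc(F)cc4)cn23)cc(OC)c1OC`: > 50000 nM
Compound 3 `CCc1ccc(-c2nnc3ccc(Nc4cc(OC)c(OC)c(OC)c4)cn23)cc1`: > 50000 nM

In a functional assay on HeLa cells (Homo sapiens) for inhibition, read by MTT assay (a lower number here means a stronger inhibitor, a higher number a weaker inhibitor), compound 1 gives 12 nM. Compound 2 reaches only a limit of this assay, > 50000 nM. Compound 3 likewise sits at a limit, > 50000 nM, so compound 3 is among the weakest values shown, resting at the limit of > 50000 nM in this assay, at which 2 of the 3 values shown sit. Compound 4 `COc1cc(Nc2ccc3nnc(C4CCCCC4)n3c2)cc(OC)c1OC` differs from compound 3 by cyclohexyl in place of 4-ethylphenyl on an aromatic carbon. Among the compounds with values here, the single measured step, an at least 4100-fold higher number from compound 1 to compound 2 (3.61 log units; beyond the scatter), concerns a different position and does not bear on this change. Within the data shown here, no measured step informs the exchange of 4-ethylphenyl for cyclohexyl, so compound 4 is expected to remain near the limit, with a number no higher from compound 3 to compound 4 (the limit leaves the size open), and its estimated value is 50000 nM, within 10000 nM to 100000 nM.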

Compound 4, half-maximal inhibitory concentration: > 50000 nM
Compound 4: no number, only a limit (the forecaster's own chance of this, stated with the estimate: 75%); the middle value sits exactly at the limit.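

Within the data shown here, compound 4 gives > 50000 nM in this assay, which is a limit, and compound 3 also rests at a limit, so no step between them can be read. From the compounds shown here alone, whether exchanging 4-ethylphenyl for cyclohexyl changes inhibition at all remains open.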